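This account rests on a few compounds, and the source may have more. Where it says the series, first, only, none or still open, it means among the compounds named here.

Compound 2 `O=C1C=C(N2CCNCC2)CN1c1ccc(Cl)cc1` carries a piperazin-1-yl group on its core, and in a functional assay on the whole organism (strain NMRI BR) with Mus musculus as the target (on this read-out lower numbers stand for an effect already at smaller amounts and higher numbers for an effect only at larger amounts of compound), compound 2 gives 58.2 mg/kg. Compound 1 `O=C1C=C(N2CCCC2)CN1c1ccc(Cl)cc1` differs from it by pyrrolidin-1-yl in place of piperazin-1-yl on a double-bonded ring carbon. In this assay compound 1 reaches only the limit of > 300 mg/kg. The step of an at least 5.1-fold higher number from compound 2 to compound 1 (0.71 log units; beyond the scatter) therefore rests on the limit of > 300 mg/kg in this assay, at which 1 of the 3 values shown sits, and marks a floor. Compound 3 `O=C1C=C(N2CCNCC2)C(=O)N1c1ccc(F)cc1` has a different core; how its core differs from that of compound 2 is not broken down here. In this assay compound 3 gives 289 mg/kg. Compound 4 `O=C1C=C(N2CCCC2)C(=O)N1c1ccc(F)cc1` differs from compound 3 by pyrrolidin-1-yl in place of piperazin-1-yl on a double-bonded ring carbon, the same change as between compound 2 and compound 1. The step of a 3.5-fold higher number from compound 3 to compound 4 (0.54 log units; beyond the scatter) is expected, because the earlier step of an at least 5.1-fold higher number from compound 2 to compound 1 (0.71 log units; beyond the scatter) already carried compound 1 to the limit of > 300 mg/kg in this assay, at which 1 of the 3 values shown sits, while compound 3 starts close to that limit. Compound 4 is thus expected to give 1000 mg/kg, most likely reported only as a limit.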

Compound 4, dose for half-maximal effect: > 200 mg/kg
Compound 4: only a limit was reported (the forecaster's own chance of this, stated with the estimate: 80%); the middle value lies beyond the limit too.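

In this assay compound 4 reaches only a limit, so the step from compound 3 to compound 4 cannot be read. The compounds shown leave open how large the change from piperazin-1-yl to pyrrolidin-1-yl is on this core.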